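Methyl to hydrogen on an amide-type nitrogen

A few compounds are considered here, and "the series" means these few. Any claim that something is new, unique, unknown or untested is made for them only; others in the source may bear on it.

Measured so far:
- compound 1 `CC(NC(=O)NS(=O)(=O)c1ccc(Cl)cc1)c1cc(Br)ccc1OCc1ccccc1`: 57500 nM
- compound 2 `CC(C)Oc1ccc(Br)cc1C(C)NC(=O)N(C)S(=O)(=O)c1ccc(Cl)cc1`: 43200 nM

Both values come from a functional assay on thoracic aorta (Rattus norvegicus, strain Wistar), with a stated time of 15 min; on this read-out higher numbers stand for an effect only at larger amounts of compound and lower numbers for an effect already at smaller amounts. Compound 2 stands at 43200 nM, within the usual scatter of compound 1 at 57500 nM, so the two cannot be separated on these numbers.

Compound 3 `CC(C)Oc1ccc(Br)cc1C(C)NC(=O)NS(=O)(=O)c1ccc(Cl)cc1` has not yet been measured. Its structure follows from compound 2 by one change: hydrogen in place of methyl on an amide-type nitrogen, with hydrogen in place of methyl on an amide-type nitrogen.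

Among the measured compounds shown here, no measured pair isolates this change. Compound 1 already carries hydrogen on that nitrogen, though it also differs elsewhere, and at 57500 nM it gives no sign of a large effect from that hydrogen. A small step is therefore expected in this assay, with a slight lean toward a lower number that the data do not establish. The expected step is a 1.4-fold lower number from compound 2 to compound 3 (0.16 log units; within the scatter).

For compound 3 the estimated value is 30000 nM, with an expected range of 10000 nM to 80000 nM.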

Compound 3, half-maximal effective concentration: 122000 nM
The estimate for compound 3 lay 4.1-fold (0.61 log units) below the measured number; measured number outside the range, above it.
By their numbers in this assay, from the lowest: compounds 2 and 1 (each within the scatter of the next); then compound 3.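

In this assay, hydrogen in place of methyl on the amide-type nitrogen whose other neighbours are the carbonyl carbon and the sulfonyl sulfur gives a 2.8-fold higher number from compound 2 to compound 3 (0.45 log units; beyond the scatter), so this position is not silent, and in this pair the methyl goes with effect at smaller amounts. The oxygen on the aromatic ring also responds: isopropyl in place of benzyl gives a 2.1-fold higher number from compound 1 to compound 3 (0.33 log units; beyond the scatter), so with hydrogen on the nitrogen the benzyl compound, compound 1, needs less compound than the isopropyl compound, compound 3. Both steps are modest, each rests on a single pair, and nothing shown explains either of them.

Still open, going by these compounds, is whether the methyl step holds with benzyl on the oxygen, since the steps at the two places share only compound 3 and say nothing about how the two changes combine. Also open, on these data alone, is how an ethyl group on the amide-type nitrogen, or a methyl or a longer chain on the oxygen in place of isopropyl, would read in this assay, and so whether either trend extends beyond these three compounds.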